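Oxanilate notes: isopropoxy in place of diethylamino

The source may hold more compounds than are shown below. What is called first, only, known or untested is meant among the compounds shown, and "the series" means these compounds.

Values in a functional assay on the whole organism with Rattus norvegicus as the target; on this read-out higher numbers stand for an effect only at larger amounts of compound and lower numbers for an effect already at smaller amounts:
- compound 1 `CCCCNc1cccc(NC(=O)C(=O)OCC)c1C#N`: 0.3 mg/kg
- compound 2 `CCOC(=O)C(=O)Nc1cccc(N(CC)CC)c1C#N`: 0.9 mg/kg
- compound 3 `CCOC(=O)C(=O)Nc1cccc(OC(C)C)c1C#N`: not yet measured

Going by the values given here, of the two measured compounds, compound 2 carries the higher number, and compound 1 is its only neighbour. Compound 3 differs from compound 2 as follows: isopropoxy in place of diethylamino on an aromatic carbon. Among the compounds with values here, one measured step bears on this change, at the same aromatic carbon: a 3.0-fold higher number from compound 1 to compound 2 (0.48 log units; beyond the scatter). That step is modest and beyond the scatter. Within the data shown here, no measured compound carries isopropoxy, so the direction remains open. A step no larger in this assay is expected, leaning slightly towards a lower number. The expected step is a 1.5-fold lower number from compound 2 to compound 3 (0.18 log units; within the scatter). The estimate for compound 3 is 0.6 mg/kg, with an expected range of 0.2 mg/kg to 1.8 mg/kg.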

Compound 3, dose for half-maximal effect: 1 mg/kg
For compound 3 the middle estimate is 1.7-fold (0.22 log units) below the measured one, within the range that was stated.
By their numbers in this assay, from the lowest: compound 1; then compounds 2 and 3 (each within the scatter of the next).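

At the aromatic carbon ortho to a cyano group, isopropoxy and diethylamino cannot be told apart in this assay (a 1.1-fold higher number from compound 2 to compound 3 (0.05 log units; within the scatter)), so this position accepts an oxygen-linked group as well as a nitrogen-linked one. Butylamino remains set apart from isopropoxy too (a 3.3-fold higher number from compound 1 to compound 3 (0.52 log units; beyond the scatter)), leaving compound 1 lowest of the three in this assay. No available evidence explains this pattern. Open, as far as these compounds go, is whether butoxy would match butylamino or isopropoxy, and how a carboxylic acid in place of the ethyl ester would fare.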